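Swapping nitro for trifluoromethoxy on the urea's aryl ring

This account rests on a few compounds, and the source may have more. Where it says the series, first, only, none or still open, it means among the compounds named here.

compound 1 `CC1(C)CCNc2ccc(NC(=S)Nc3ccc(C(F)(F)F)cc3)cc21`: 6000 nM
compound 2 `CC1(C)CC[N+](C)(C)c2ccc(NC(=O)Nc3ccc([N+](=O)[O-])cc3)cc21`: 6600 nM
compound 3 `CN1c2ccc(NC(=O)Nc3ccc([N+](=O)[O-])cc3)cc2C(C)(C)C(O)C1(C)C`: 8400 nM

All three values come from a functional assay on A2780 cells (Homo sapiens) for inhibition, with a stated time of 72 h; on this read-out higher numbers stand for weaker inhibition and lower numbers for stronger inhibition. Compound 3, at 8400 nM, lies within the usual scatter of both compound 1 and compound 2, so these three compounds cannot be separated on the numbers. Compound 4 `CN1c2ccc(NC(=O)Nc3ccc(OC(F)(F)F)cc3)cc2C(C)(C)C(O)C1(C)C` has trifluoromethoxy in place of nitro on an aromatic carbon, para to a large group: trifluoromethoxy in place of nitro on an aromatic carbon. Among the compounds with values here, no pair of measured compounds differs at this place alone, so the data offer no direct precedent for the change. The nearest indication is compound 1, which carries no nitro and also differs elsewhere, yet gives 6000 nM, within the scatter of compound 3. On that basis, no step beyond the scatter is expected in this assay. The estimated step is a 1.2-fold lower number from compound 3 to compound 4 (0.08 log units; within the scatter), and it is expected to stay inside the scatter. For compound 4 the estimated value is 7000 nM, with an expected range from 2500 nM to 20000 nM.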

Compound 4, half-maximal inhibitory concentration: 7800 nM
Estimate against measurement, compound 4: 1.1-fold (0.05 log units) below; the range from low to high includes it.
By their numbers in this assay, from the lowest: compounds 1, 2, 4 and 3 (each within the scatter of the next).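

In this assay, this place on the aromatic ring now has its first direct comparison: trifluoromethoxy in place of nitro gives a 1.1-fold lower number from compound 3 to compound 4 (0.03 log units; within the scatter), a step within the scatter. On this shared core, therefore, the nitro group is not needed to keep the read-out where it stands, as the two compounds cannot be separated despite the different groups on that aromatic carbon. Nothing further is at hand that would account for this result.

The compounds shown leave open whether this place would also accept a quite different group, such as an amine, a carboxylic acid or a longer chain. They also leave open whether the same swap would behave alike on another core, as compound 1 and compound 2 differ from compound 4 in more than one place.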